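Swapping a Carbamoylphenyl Group for a Methylpyrazole

This account rests on a few compounds, and the source may have more. Where it says the series, first, only, none or still open, it means among the compounds named here.

Compound 1, `O=c1n(Cc2cc3cnccc3n2CCCCF)c2cnccc2n1C1CC1`, gives > 50000 nM in an ADME assay on HeLa cells (Homo sapiens) for cytotoxicity, read by ATP content, with a stated time of 3 days; a higher number here means that more compound is tolerated, a lower number that less compound is tolerated; this value is a limit of the assay, not a number.
Compound 2, `CS(=O)(=O)CCCn1c(Cn2c(=O)n(C3CC3)c3ccncc32)nc2nc(Cl)ccc21`, gives > 50000 nM in this assay; this too is a limit.
Compound 3, `N#CCCCn1c(Cn2c(=O)n(-c3ccc(C(=O)NC4CC4)cc3)c3ccncc32)cc2cc(Cl)ccc21`, gives > 50000 nM in this assay; again a limit.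

Compound 3 therefore stands where every measured compound stands: at the limit of > 50000 nM in this assay, at which 3 of the 3 values shown sit. No difference between any two of these compounds can be read from the numbers, since none of them is a number.

Compound 4, `Cn1ccc(-n2c(=O)n(Cc3cc4cc(Cl)ccc4n3CCCC#N)c3cnccc32)n1`, differs from compound 3 in one place: 1-methyl-1H-pyrazol-3-yl in place of 4-(cyclopropylcarbamoyl)phenyl on an aromatic nitrogen. Among the compounds with values here, there is no measured pair here that isolates this change, so nothing in the data speaks for a shift in either direction.

With three compounds of the shared core all sitting at the limit, compound 4 is expected to sit there as well, with a step from compound 3 of a step that the limit leaves unreadable from compound 3 to compound 4, that is, none beyond the usual scatter. The estimate for compound 4 in this assay is 55000 nM, with a range from 30000 nM to 100000 nM.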

Compound 4, half-maximal cytotoxic concentration: > 50000 nM
Compound 4: no number, only a limit; the forecaster's own chance of this, stated with the estimate: 85%; the middle value does not contradict the limit.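

Within the data shown here, compound 3 and compound 4 both give a limit of the assay rather than a number, so no step between them can be read: the limit of > 50000 nM in this assay, at which 4 of the 4 values shown sit.
The compounds shown leave open at what concentration any of them would become cytotoxic in this assay and whether swapping these two groups changes that concentration.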